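Aryl piperazine series: methoxy for fluoro on compound 3

The source may hold more compounds than are shown below. What is called first, only, known or untested is meant among the compounds shown, and "the series" means these compounds.

In a functional assay on MCF7 cells (Homo sapiens) for inhibition, read by MTT assay (on this read-out higher numbers stand for weaker inhibition and lower numbers for stronger inhibition), compound 3 `O=C(CN1CCN(c2ccccc2F)CC1)Nc1ccc(C(=O)/C=C/c2cn(Cc3ccc(Br)cc3)nn2)cc1` gives 11300 nM, the lowest of the two numbers shown. Compound 1 `CCCCCCCCn1cc(/C=C/C(=O)c2ccc(NC(=O)CN3CCN(c4ccccc4F)CC3)cc2)nn1` gives 68600 nM, and the step between them is a 6.1-fold lower number from compound 1 to compound 3 (0.78 log units; beyond the scatter). Compound 2 `CCCCCCCCCCn1cc(/C=C/C(=O)c2ccc(NC(=O)CN3CCN(c4ccccc4)CC3)cc2)nn1` returns only a limit, > 100000 nM. Compound 4 `COc1ccccc1N1CCN(CC(=O)Nc2ccc(C(=O)/C=C/c3cn(Cc4ccc(Br)cc4)nn3)cc2)CC1` keeps the whole of compound 3 except that (methoxy in place of fluoro on an aromatic carbon). For the measured compounds named here, no measured step bears on this position: the single step on record, a 6.1-fold lower number from compound 1 to compound 3 (0.78 log units; beyond the scatter), concerns the group on the saturated chain carbon bound to the aromatic nitrogen and says nothing about the 2-fluorophenyl to 2-methoxyphenyl exchange. The expected step of a 1.0-fold lower number from compound 3 to compound 4 (0.01 log units; within the scatter) is therefore set at no change beyond the scatter, with wide uncertainty. Compound 4 is estimated at 11000 nM, range 3500 nM to 35000 nM.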

Compound 4, half-maximal inhibitory concentration: 36800 nM
Compound 4: middle estimate off by 3.3-fold (0.52 log units), on the low side; the measured number lies above the stated range.
By their numbers in this assay, from the lowest: compound 3; then compounds 4 and 1 (each within the scatter of the next). At a limit, above all of these: compound 2.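

In this assay the position on the aromatic ring does respond: 2-methoxyphenyl in place of 2-fluorophenyl, with the 4-bromophenyl group held constant, gives a 3.3-fold higher number from compound 3 to compound 4 (0.51 log units; beyond the scatter), a modest weakening of inhibition. For the compounds shown here, this is the first measured reading at this position, and here fluoro gives the stronger inhibition of the two. No available measurement gives a cause for this step.

On these data alone, whether the step holds with the chain of compound 1, and how an amine or a hydroxyl group would read at this position, stays open. Compound 2, with plain phenyl here but a different chain, gives only a limit, > 100000 nM.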